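Removing one methoxy from compound 2

A few compounds are considered here, and "the series" means these few. Any claim that something is new, unique, unknown or untested is made for them only; others in the source may bear on it.

Compound 2 `COc1ccc(CNCCCNS(=O)(=O)c2cc(C(F)(F)F)cc(C(F)(F)F)c2)cc1OC` gives 15000 nM in a functional assay on Capan-2 cells (Homo sapiens) for inhibition, read by MTT assay, with a stated time of 72 h (on this read-out lower numbers stand for stronger inhibition of growth and higher numbers for weaker inhibition of growth), the highest number among the three measured. Compound 3 `O=S(=O)(NCCCNCc1ccccc1)c1cc(C(F)(F)F)cc(C(F)(F)F)c1` gives 14000 nM, and the difference is a 1.1-fold lower number from compound 2 to compound 3 (0.03 log units; within the scatter). Compound 1 `O=S(=O)(NCCCCNCc1ccc(Br)cc1)c1cc(C(F)(F)F)cc(C(F)(F)F)c1` gives 1900 nM, with a 7.4-fold higher number from compound 1 to compound 3 (0.87 log units; beyond the scatter). Compound 4 `COc1ccc(CNCCCNS(=O)(=O)c2cc(C(F)(F)F)cc(C(F)(F)F)c2)cc1` differs from compound 2 by hydrogen in place of methoxy on an aromatic carbon. For the measured compounds named here, the measured step that bears on this is the one from compound 2 to compound 3, where phenyl in place of 3,4-dimethoxyphenyl left the number within the scatter; the step from compound 1 to compound 3 changes another part of the molecule and carries less weight here. With only one methoxy removed, the expected step is a 1.1-fold lower number from compound 2 to compound 4 (0.03 log units; within the scatter), none beyond the scatter. Compound 4 is therefore estimated at 14000 nM, with a range from 5000 nM to 40000 nM.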

Compound 4, concentration for 50% growth inhibition: 2400 nM
Estimate against measurement, compound 4: 5.8-fold (0.77 log units) above; measured number below the stated range.
By their numbers in this assay, from the lowest: compounds 1 and 4 (each within the scatter of the next); then compounds 3 and 2 (each within the scatter of the next).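

In this assay the steps of a 6.3-fold lower number from compound 2 to compound 4 (0.80 log units; beyond the scatter) and a 5.8-fold lower number from compound 3 to compound 4 (0.77 log units; beyond the scatter) set the 4-methoxyphenyl ring apart from both the 3,4-dimethoxyphenyl and the phenyl rings, so the two methoxy groups cannot be read one at a time. The step of a 1.3-fold higher number from compound 1 to compound 4 (0.10 log units; within the scatter) puts compound 4 level with compound 1, which carries a 4-bromobenzyl group on its chain. Nothing at hand explains why removing this one methoxy matters when removing both does not.

Going by these compounds, whether an ethoxy, a hydroxyl or a fluorine in place of the remaining methoxy of compound 4 holds this level stays open.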